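The source may report more compounds than this note shows. Statements on the series, on what has been measured and on what is new or still open speak of the compounds shown alone.

Measured so far:
compound 1 `c1coc(-c2ccccc2NCC2=NCCN2)c1` gives 6.31 nM
compound 2 `c1ccc(-c2ccccc2NCC2=NCCN2)nc1` gives 30.2 nM

Both numbers come from a functional assay for activation of Alpha-1B adrenergic receptor (Homo sapiens), read by calcium flux; on this read-out higher numbers stand for an effect only at larger amounts of compound and lower numbers for an effect already at smaller amounts. Of the two, compound 2 stands at the higher number; its nearest neighbour is compound 1, and the change was a 4.8-fold higher number from compound 1 to compound 2 (0.68 log units; beyond the scatter), a swap of one aromatic ring for another on the shared core.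

Compound 3 `CC/C(=N/OC)c1ccccc1NCC1=NCCN1` carries a different kind of change: a group of 6 heavy atoms (4 carbon, 1 nitrogen, 1 oxygen; no ring) in place of a group of 6 heavy atoms (5 carbon, 1 nitrogen; one six-membered aromatic ring with 1 hetero atom), on an aromatic carbon. For the measured compounds named here, the one measured step, swapping one ring for another, moved the number by a 4.8-fold higher number from compound 1 to compound 2 (0.68 log units; beyond the scatter); no measured pair shows what happens when the ring is replaced by an open chain with a double bond, so the direction is uncertain and the size could be larger than the single step seen. Compound 3 is therefore expected near 35 nM, within 8 nM to 160 nM. The step this estimate implies, a 1.2-fold higher number from compound 2 to compound 3 (0.06 log units; within the scatter), is expected to stay within the scatter.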

Compound 3, half-maximal effective concentration: < 5020 nM
Compound 3: no number, only a limit; the forecaster's own chance of this, stated with the estimate: 5%; the middle value does not contradict the limit.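

Compound 3 gives only a limit, < 5020 nM, and not a number. The steps to it from compound 1 and compound 2 cannot be read. Still open, on these data alone, is how the open chain of compound 3 compares with the aromatic rings of compound 1 and compound 2.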